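Swapping dimethylamino for hydroxy on compound 1

The source may hold more compounds than are shown below. What is called first, only, known or untested is meant among the compounds shown, and "the series" means these compounds.

Measured in a functional assay, with a stated time of 10 min; a higher number here means a weaker inhibitor, a lower number a stronger inhibitor:
- Compound 1 `CN(C)c1ccc(/C=C/c2cc(=O)c(O)co2)cc1`: 3050 nM
- Compound 2 `COc1ccccc1/C=C/c1cc(=O)c(O)co1`: 3470 nM
- Compound 3 `COc1cc(/C=C/c2cc(=O)c(O)co2)cc(OC)c1`: 1790 nM

Compound 1 lies within the usual scatter of both compound 2 and compound 3, so these three cannot be ranked. Compound 4 `O=c1cc(/C=C/c2ccc(O)cc2)occ1O` has hydroxy in place of dimethylamino on an aromatic carbon, para to a large group: hydroxy in place of dimethylamino on an aromatic carbon. For the measured compounds named here, no measured pair shows this change alone. Compound 2 at 3470 nM and compound 3 at 1790 nM carry other groups, yet neither leaves the scatter of compound 1, so a large shift seems unlikely. The expected step of a 1.7-fold lower number from compound 1 to compound 4 (0.23 log units; within the scatter) leans slightly towards a lower number but stays within the scatter. For compound 4 the estimated value in this assay is 1800 nM, with an expected range from 500 nM to 5000 nM.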

Compound 4, half-maximal inhibitory concentration: 1940 nM
Beside the measured number, compound 4's estimate is 1.1-fold (0.03 log units) below it; low and high end bracket the measured number.
By their numbers in this assay, from the lowest: compounds 3, 4, 1 and 2 (each within the scatter of the next).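

In this assay the direct comparison of this change gives one step (a 1.6-fold lower number from compound 1 to compound 4 (0.20 log units; within the scatter)), and it lies within the scatter. On this aromatic carbon, para to a large group, hydroxy therefore takes the place of dimethylamino with no measurable difference, even though it brings a hydrogen-bond donor that dimethylamino lacks. No supporting measurement bears on why this is so. Still open, from the compounds shown here alone, is whether another group at this place, such as a carboxylic acid or a longer chain, would give a number beyond the scatter.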